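Chlorine and a Shorter Chain: From Compound 3 to Compound 4

The source may hold more compounds than are shown below. What is called first, only, known or untested is meant among the compounds shown, and "the series" means these compounds.

Of the compounds shown here, three sharing a piperazine-linked benzodioxane core have been tested in a functional assay on the whole organism for antagonist activity, with Rattus norvegicus as the target; a lower number here means that less compound is needed, a higher number that more compound is needed for the effect. Compound 1 `C1=C(CCN2CCN(c3cccc4c3OCCO4)CC2)c2ccccc2CC1` gives 0.63 mg/kg, compound 2 `Clc1cccc2c1CC2CCN1CCN(c2cccc3c2OCCO3)CC1` gives 1.25 mg/kg, and compound 3 `c1ccc2c(c1)CC2CCCCN1CCN(c2cccc3c2OCCO3)CC1` gives 5 mg/kg. Compound 3 thus needs the highest dose of the three, with its separation from compound 2 and from compound 1 both beyond the usual scatter of this assay.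

Compound 4 `Clc1cccc2c1CC2CCCN1CCN(c2cccc3c2OCCO3)CC1` has not yet been measured. It differs from compound 3 by a group of 9 heavy atoms (8 carbon, 1 chlorine; one four-membered non-aromatic ring of carbon only, one six-membered aromatic ring of carbon only) in place of a group of 9 heavy atoms (9 carbon; one four-membered non-aromatic ring of carbon only, one six-membered aromatic ring of carbon only), on a saturated chain carbon, three bonds along the chain from an amine nitrogen in a ring. Going by the values given here, no direct pair among the measured compounds isolates this change, so the expectation rests on the neighbourhood: compound 2, which also carries a chlorine on its four-membered ring system and a shorter chain, gives 1.25 mg/kg, a lower dose than compound 3.

On that basis, compound 4 is expected to need less compound than compound 3, with an estimated step of a 3.3-fold lower number from compound 3 to compound 4 (0.52 log units; beyond the scatter). Compound 4 is estimated at 1.5 mg/kg, likely between 0.6 mg/kg and 5 mg/kg in this assay.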

Compound 4, minimum effective dose: 0.63 mg/kg
Compound 4: the middle estimate sits 2.4-fold (0.38 log units) above what was measured; measured number inside the range.
By their numbers in this assay, from the lowest: compounds 1, 4 and 2 (each within the scatter of the next); then compound 3.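

In this assay, going by these compounds alone, the swap on this saturated chain carbon, three bonds along the chain from an amine nitrogen in a ring, gives a 7.9-fold lower number from compound 3 to compound 4 (0.90 log units; beyond the scatter) and is the first step here between measured compounds that differ in one place. The step is clear even though both groups have 9 heavy atoms, the same two rings, and no hydrogen-bond donors or acceptors, so what changes is 8 carbon and 1 chlorine in place of 9 carbon. No measurement shown explains why the dose falls.

The chlorine and the shorter chain arrive together, so the compounds shown cannot tell how much of the step belongs to each. As far as these compounds go, it also remains open whether a fluorine or a methyl group in place of the chlorine would give a similar dose.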